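Dihydropyridine series: moving from 2,6-dichlorophenyl to 2,4-dichlorophenyl

The source may report more compounds than this note shows. Statements on the series, on what has been measured and on what is new or still open speak of the compounds shown alone.

Of the compounds shown here, three of the shared core have been measured in a functional assay (muscle tissue) with Cavia porcellus as the target; a higher number here means that more compound is needed for the effect, a lower number that less compound is needed. Compound 1 `COC(=O)C1=C(C)N=C(C)/C(=C(/O)OC)C1c1c(F)cccc1Cl` gives 7.59 nM. Compound 2 `COC(=O)C1=C(C)N=C(C)/C(=C(\O)OC)C1c1cccc(OC(C)=O)c1` gives 6030 nM. Compound 3 `COC(=O)C1=C(C)N=C(C)/C(=C(\O)OC)C1c1c(Cl)cccc1Cl` gives 1.91 nM, the lowest of the three numbers; the nearest is compound 1, whose number is higher by a margin beyond the scatter, and the furthest is compound 2, whose number is higher by a very wide margin, also beyond the scatter. Among the compounds with values here, no pair among the three differs in a single place, so no single step can be read off; what can be said is that the two compounds carrying a halogen on each side of the attachment, compound 1 and compound 3, both sit at low numbers, while compound 2 with its acetoxy group sits far higher.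

Compound 4 `COC(=O)C1=C(C)N=C(C)/C(=C(\O)OC)C1c1ccc(Cl)cc1Cl` is not yet measured. It differs from compound 3 in one place: 2,4-dichlorophenyl in place of 2,6-dichlorophenyl on a saturated ring carbon. One chlorine stays where it was; the other moves. Within the data shown here, with no measured step to rest on, a rise of moderate size, at or somewhat beyond the scatter, is expected rather than a drop, given how low compound 3 sits at 1.91 nM. The step from compound 3 to compound 4 is estimated as a 4.7-fold higher number from compound 3 to compound 4 (0.67 log units; beyond the scatter). Compound 4 is expected to give about 9 nM in this assay, within 2.5 nM to 40 nM.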

Compound 4, half-maximal effective concentration: 640 nM
Estimate against measurement, compound 4: 71-fold (1.85 log units) below; measured number above the stated range.
By their numbers in this assay, from the lowest: compound 3; then compound 1; then compound 4; then compound 2.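

In this assay, within the data shown here, moving one chlorine on the aryl group at this saturated ring carbon gives a 340-fold higher number from compound 3 to compound 4 (2.53 log units; beyond the scatter), the first step that can be read, and it is large. The 2,6-dichlorophenyl and 2,4-dichlorophenyl groups have the same atoms and the same printed counts, so at this position composition alone does not set the number; the placement of the chlorines on the aromatic ring matters a great deal. Among these compounds, two chlorines on the aryl group are therefore not enough for a low number, as compound 4 gives 640 nM, which the earlier compounds could not show.

Nothing available here bears on the reason for this step. Still open, from the compounds shown here alone, are whether the step comes from the chlorine lost from its old place or the chlorine gained in its new one, and whether an amine or a nitrile in place of the moved chlorine on this ring would give a low number or a high one.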